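The source may report more compounds than this note shows. Statements on the series, on what has been measured and on what is new or still open speak of the compounds shown alone.

Among the compounds with values here, compound 2 `NS(=O)(=O)c1ccc(-c2cnc(C(=O)CCCCCCc3ccccc3)o2)s1` holds the lowest of the two numbers so far in an assay (Rattus norvegicus) for inhibition of Fatty-acid amide hydrolase 1 (Homo sapiens); on this read-out lower numbers stand for stronger inhibition and higher numbers for weaker inhibition: compound 2 gives 3 nM, whereas compound 1 `O=C(CCCCCCc1ccccc1)c1ncc(-c2ccccc2F)o1` gives 110 nM. Within the data shown here, the one measured step, a 37-fold lower number from compound 1 to compound 2 (1.56 log units; beyond the scatter), is the only guide, and it bears on the change to compound 3 `O=C(CCCCCCc1ccccc1)c1ncc(C(=O)N2CCOCC2)o1` only indirectly, since the change is (morpholin-4-yl)carbonyl in place of 5-sulfamoylthiophen-2-yl on an aromatic carbon: the group that brought the large gain now leaves, and what enters is not an aromatic group at all. The step from compound 2 to compound 3 is therefore expected to run upward, roughly undoing that gain, at a 50-fold higher number from compound 2 to compound 3 (1.70 log units; beyond the scatter). For compound 3 the estimate in this assay is 150 nM, with a range from 30 nM to 800 nM.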

Compound 3, inhibition constant: 24 nM
Estimate against measurement, compound 3: 6.3-fold (0.80 log units) above, outside the stated range (below it).
By their numbers in this assay, from the lowest: compound 2; then compound 3; then compound 1.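

In this assay, this position next to the ring oxygen does not need an aromatic ring for a low number: replacing 2-fluorophenyl with (morpholin-4-yl)carbonyl gives a 4.6-fold lower number from compound 1 to compound 3 (0.66 log units; beyond the scatter) and still improves on compound 1. Against 5-sulfamoylthiophen-2-yl, the same group gives an 8.0-fold higher number from compound 2 to compound 3 (0.90 log units; beyond the scatter) and so keeps only part of the earlier gain. No measurement here accounts for either step. Still open, on these data alone, is which part of each group carries the effect: a piperidine amide, a carboxylic acid or a plain thiophen-2-yl would help separate these.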